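Adding a Second Ester Promoiety to Compound 3

The source may report more compounds than this note shows. Statements on the series, on what has been measured and on what is new or still open speak of the compounds shown alone.

Compound 3 is `CCC(CC)C(=O)OCOC(=O)C1=C(S[C@@H]2CN[C@H](C(=O)Nc3cccc(C(=O)O)c3)C2)[C@H](C)[C@@H]2[C@@H]([C@@H](C)O)C(=O)N12`. In an ADME assay for metabolic stability, read by LC-MS, with a stated time of 3 h, at pH 6.5, tested at 50 uM (on this read-out lower numbers stand for a less stable compound and higher numbers for a more stable compound), compound 3 gives > 95%, which is a limit of the assay and not a number. Its two measured relatives stand at the same limit. Compound 1 is `CCOC(=O)C1=C(S[C@@H]2CN[C@H](C(=O)Nc3cccc(C(=O)O)c3)C2)[C@H](C)[C@@H]2[C@@H]([C@@H](C)O)C(=O)N12`, and in this assay compound 1 gives > 95%, a limit. Compound 2 is `CCOC(=O)OCOC(=O)C1=C(S[C@@H]2CN[C@H](C(=O)Nc3cccc(C(=O)O)c3)C2)[C@H](C)[C@@H]2[C@@H]([C@@H](C)O)C(=O)N12`, and in this assay compound 2 gives > 95%, likewise a limit. The steps a step that the two limits leave unreadable from compound 1 to compound 2, a step that the two limits leave unreadable from compound 1 to compound 3 and a step that the two limits leave unreadable from compound 2 to compound 3 therefore show nothing about size, because of the limit of > 95% in this assay, at which 3 of the 3 values shown sit.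

Compound 4 is `CCC(CC)C(=O)OCOC(=O)C1=C(S[C@@H]2CN[C@H](C(=O)Nc3cccc(C(=O)OCOC(=O)C(CC)CC)c3)C2)[C@H](C)[C@@H]2[C@@H]([C@@H](C)O)C(=O)N12`. It differs from compound 3 by (((pentan-3-yl)carbonyl)oxy)methyl in place of hydrogen on an oxygen next to a carbonyl group. Within the data shown here, none of the measured steps bears readably on this change, since every one of them runs from limit to limit, and so no size or direction can be taken from them. In this assay the expected step is a number no higher from compound 3 to compound 4 (the limit leaves the size open), that is, nothing beyond the scatter that could be read. Compound 4 is accordingly estimated at 95% in this assay, within a range from 85% to 100%, and most probably it will again be reported only as a limit.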

Compound 4, percent of the compound remaining: > 95%
Compound 4: a limit, no number; the forecaster's own chance of this, stated with the estimate: 80%; the middle value sits exactly at the limit.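

No new step can be read here: compound 3 and compound 4 stand at the same limit, so the change between them has no readable size, because the read-out stops there: the limit of > 95% in this assay, at which 4 of the 4 values shown sit.

The compounds shown leave open whether the (((pentan-3-yl)carbonyl)oxy)methyl group of compound 4 alters the percent of compound remaining at all, and in which direction.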